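The source may report more compounds than this note shows. Statements on the series, on what has been measured and on what is new or still open speak of the compounds shown alone.

Measured so far:
Compound 1 `COc1ccc(/C=C2\CCC=CC2=O)cc1OC` gives 640 nM
Compound 2 `COc1cc(/C=C2\CCC=CC2=O)cc(OC)c1` gives 600 nM

In a functional assay on MDA-MB-231 cells (Homo sapiens) for antiproliferative activity, read by sulforhodamine B assay, with a stated time of 72 h (a lower number here means a stronger inhibitor, a higher number a weaker inhibitor), compound 2 gives 600 nM and lies within the usual scatter of compound 1 (640 nM), so neither one stands apart. Compound 3 `COc1cc(/C=C2\CCC=CC2=O)cc(OC)c1OC` differs from compound 2 by methoxy in place of hydrogen on an aromatic carbon (methoxy in place of hydrogen on an aromatic carbon, ortho to two methoxy groups). Among the compounds with values here, no measured pair of compounds shows this change, so any forecast is uncertain. The expected move in this assay is a 1.7-fold lower number from compound 2 to compound 3 (0.23 log units; within the scatter) (a modest one, toward a lower number). Compound 3 is estimated at 350 nM (expected range 100 nM to 1000 nM).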

Compound 3, half-maximal inhibitory concentration: 670 nM
The estimate for compound 3 lay 1.9-fold (0.28 log units) below the measured number, and the stated range covers the measured number.
By their numbers in this assay, from the lowest: compounds 2, 1 and 3 (each within the scatter of the next).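

In this assay the new methoxy, on the aromatic carbon ortho to two methoxy groups, gives a 1.1-fold higher number from compound 2 to compound 3 (0.05 log units; within the scatter) and a 1.0-fold higher number from compound 1 to compound 3 (0.02 log units; within the scatter) so this carbon carries a third methoxy with no change beyond the scatter. Adding this group therefore leaves the number where the two-methoxy compounds already stood. No measurement at hand explains this flat result. From the compounds shown here alone, whether an amine or a carboxylic acid on this same carbon would shift the number stays open, and so does a longer chain such as ethoxy in place of the methoxy.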